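The compounds below may be only part of what the source reports. "The series", "measured", "known", "first", "only" and "open" are said of these compounds alone.

Working notes on the nitrone series.

Compound 1 `[O-]/[N+](=C\c1cn(-c2ccccc2)nn1)Cc1ccccc1` carries a benzyl group on the nitrone nitrogen and a phenyl on the triazole. In a functional assay on COLO 205 cells (Homo sapiens) for inhibition, read by MTT assay, with a stated time of 24 h (on this read-out higher numbers stand for weaker inhibition and lower numbers for stronger inhibition), compound 1 gives a limit of > 100000 nM. Compound 2 `CCCCCCCCn1cc(/C=[N+](\[O-])Cc2ccccc2)nn1` has the octyl-bearing core; the difference between the two cores is not broken down here. In this assay compound 2 also reaches only the limit of > 100000 nM. Compound 3 `CC(C)(C)/[N+]([O-])=C/c1cn(-c2ccccc2)nn1` differs from compound 1 by tert-butyl in place of benzyl on a double-bonded nitrogen; in this assay compound 3 gives 15200 nM, a step of an at least 6.5-fold lower number from compound 1 to compound 3 (0.81 log units; beyond the scatter). Its size is only a lower bound because of the limit of > 100000 nM in this assay, at which 2 of the 3 values shown sit.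

Compound 4 `CCCCCCCCn1cc(/C=[N+](\[O-])C(C)(C)C)nn1` makes the same change on the octyl core: tert-butyl in place of benzyl on a double-bonded nitrogen. Among the measured compounds shown here, a step of about an at least 5.0-fold lower number from compound 2 to compound 4 (0.69 log units; beyond the scatter) is expected from compound 2 to compound 4 in this assay, resting on the single parallel step an at least 6.5-fold lower number from compound 1 to compound 3 (0.81 log units; beyond the scatter). Compound 4 is therefore estimated at 20000 nM, with a range of 5000 nM to 100000 nM.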

Compound 4, half-maximal inhibitory concentration: 30800 nM
The estimate for compound 4 lay 1.5-fold (0.19 log units) below the measured number; the range from low to high includes it.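

In this assay, tert-butyl in place of benzyl on a double-bonded nitrogen lowers the number on the octyl core as well (an at least 3.2-fold lower number from compound 2 to compound 4 (0.51 log units; beyond the scatter)), so the direction of the change holds on both cores shown. This does not show that the change carries over with the same size: the same change on two cores in this assay, an at least 6.5-fold lower number (0.81 log units; beyond the scatter) from compound 1 to compound 3 and an at least 3.2-fold lower number (0.51 log units; beyond the scatter) from compound 2 to compound 4; the limit leaves it open whether they differ
Both steps are lower bounds only, and their true sizes stay unknown: the limit of > 100000 nM in this assay, at which 2 of the 4 values shown sit.

Still open, going by these compounds, is whether the direction holds with other groups on that nitrogen, such as isopropyl or cyclohexyl. Also open, on these data alone, is how the number responds when octyl or phenyl gives way to a longer chain such as dodecyl, or to a chain ending in an amine or a carboxylic acid.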